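The compounds below may be only part of what the source reports. "The series", "measured", "known", "first", "only" and "open" are said of these compounds alone.

Two compounds carry numbers here. Compound 1 `N#Cc1ccc(N2CCN(Cc3cn4cc(Cl)ccc4n3)CC2)nc1` and compound 2 `CCc1nc(CN2C[C@H](C(=O)NCc3ccccc3Cl)[C@@H](c3cccnc3)C2)c[nH]1` were both tested in a functional assay on CHO-K1 cells for agonist activity at G-protein coupled receptor 39 (Homo sapiens), read by cAMP accumulation, with stated times of 30 min and 60 min; on this read-out lower numbers stand for smaller maximal responses and higher numbers for larger maximal responses. In this assay compound 1 gives 100%, and compound 2 gives 107%; the two values lie within the usual scatter of each other, so compound 2 cannot be said to stand apart from compound 1 on maximal response.

Compound 3 `CCc1nc(CN2C[C@@H](C(=O)NCc3ccccc3Cl)[C@H](c3cccnc3)C2)c[nH]1` is the partner of compound 2. The difference is the two compounds have the same atoms and bonds and differ only in configuration as drawn: 2 of 2 stereo elements differ (all stereocentres are inverted: mirror images); a stereocentre at a saturated ring carbon is drawn R in compound 2 and S in compound 3; a stereocentre at a saturated ring carbon is drawn S in compound 2 and R in compound 3. For the measured compounds named here, no measured pair in this set shows what such a full inversion does in this assay, so the size of the step is open: a mirror image may keep the full response or may lose most of it.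

Compound 3 is therefore estimated at 80%, with a range from 25% to 115%. The expected step of a number 27 percentage points lower from compound 2 to compound 3 (beyond the scatter) is downward but with wide uncertainty.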

Compound 3, largest response reached (reported as efficacy), in percent of the reference or control that the assay uses in the G-protein coupled receptor 39 assay: 99%
Estimate against measurement, compound 3: 19 percentage points below; the range from low to high includes it.
By their numbers in the G-protein coupled receptor 39 assay, from the lowest: compounds 3, 1 and 2 (each within the scatter of the next).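

Full inversion of both stereocentres is a change the earlier compounds could not speak to, and in the G-protein coupled receptor 39 assay it appears as a number 8 percentage points lower from compound 2 to compound 3 (within the scatter), so the two mirror images cannot be told apart on maximal response. In a physicochemical assay for permeability (a higher number here means that the compound crosses the layer faster, a lower number that the compound crosses the layer more slowly), compound 2 gives 1.2 10^-6 cm/s and compound 3 gives 0.8 10^-6 cm/s, two values that also lie within the usual scatter of each other. This pair therefore isolates configuration as the only variable, and neither read-out separates its members: the fact that compounds 2 and 3 differ only in the configuration as drawn

The compounds shown leave open whether the mirror images also match in the concentration needed for this response, and what inverting only one stereocentre would do. They also do not show how a carboxylic acid or an amine on the shared core would fare in either configuration.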